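The source may hold more compounds than are shown below. What is called first, only, known or untested is meant among the compounds shown, and "the series" means these compounds.

Going by the values given here, compound 2 `O=C(Nc1nc(-c2ccccc2)nc2c1nnn2Cc1ccccc1)c1cccc(F)c1` gives 22 nM in an assay (strain Wistar) for displacement of a labelled ligand from adenosine receptor A1 (Rattus norvegicus), read by scintillation counting (a lower number here means a stronger inhibitor, a higher number a weaker inhibitor), and holds the lowest of the two numbers obtained so far; the only other measured member, compound 1 `COc1ccccc1C(=O)Nc1nc(-c2ccccc2)nc2c1nnn2Cc1ccccc1`, gives 1520 nM in this assay. Among the compounds with values here, the one step measured between them reads a 69-fold lower number from compound 1 to compound 2 (1.84 log units; beyond the scatter). Compound 3 `O=C(Nc1nc(-c2ccccc2)nc2c1nnn2Cc1ccccc1)C1CCCC1` differs from compound 2 by cyclopentyl in place of 3-fluorophenyl on a carbonyl carbon. Within the data shown here, the earlier step exchanged one six-membered aromatic ring for another and is the sole comparison in hand, so it bears on the present change only loosely: it shows that the group on the carbonyl carbon can shift the number a long way, but gives no direct read on an exchange of an aromatic ring for a non-aromatic one. Nothing in the series fixes the direction for compound 3. A moderate step in this assay is therefore expected, more likely towards a higher number than a lower one, with wide uncertainty either way. The expected step is a 2.7-fold higher number from compound 2 to compound 3 (0.44 log units; beyond the scatter). For compound 3 the number is estimated at 60 nM, within a range of 10 nM to 400 nM.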

Compound 3, inhibition constant: 2.5 nM
For compound 3 the middle estimate is 24-fold (1.38 log units) above the measured one; the whole stated range lies above it.
By their numbers in this assay, from the lowest: compound 3; then compound 2; then compound 1.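

The step of an 8.8-fold lower number from compound 2 to compound 3 (0.94 log units; beyond the scatter) in this assay shows that the group on the carbonyl carbon need not be aromatic, and that a five-membered non-aromatic ring of carbon only gives the lowest number of the three compounds, with its steps to both others beyond the scatter. The step of a 610-fold lower number from compound 1 to compound 3 (2.78 log units; beyond the scatter) widens the range seen at this one position well past what the two aromatic members showed, so the choice of group here governs the number in this assay more strongly than compounds 1 and 2 alone indicated. No measurement in hand accounts for the lower number with cyclopentyl.

Still open, as far as these compounds go, is whether this result belongs to cyclopentyl itself or extends to non-aromatic groups on this carbonyl carbon more widely, a question that cyclobutyl, cyclohexyl or an open chain such as isobutyl would address. Also open is how a cyclopentyl ring carrying a hydroxyl group, an amine or a carboxylic acid would read in this assay, since every group shown so far on this carbonyl carbon is a ring with no such substituent.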